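The source may hold more compounds than are shown below. What is called first, only, known or untested is meant among the compounds shown, and "the series" means these compounds.

Measured compounds:
compound 1, `COc1ccc2nc(Cl)c(/C=C3\SC(=S)NC3=O)cc2c1`, > 100 ug/mL
compound 2, `COc1ccc2cc(/C=C3\SC(=S)NC3=O)c(Cl)nc2c1`, > 100 ug/mL

In a toxicity assay on HUVEC cells (Homo sapiens) for cytotoxicity, read by MTT assay, with a stated time of 48 h (a higher number here means a weaker inhibitor of growth, a lower number a stronger inhibitor of growth), compound 1 gives only a limit, not a number: it sits at the limit of > 100 ug/mL in this assay, at which 2 of the 2 values shown sit. The value shown for compound 2 is likewise a limit. Compound 3, `O=C1NC(=S)S/C1=C\c1cc2cc(F)ccc2nc1Cl`, differs from compound 1 by fluoro in place of methoxy on an aromatic carbon. Going by the values given here, no measured pair shows what this change does here, so the step is expected to be a step that the limit leaves unreadable from compound 1 to compound 3, that is, nothing beyond the usual scatter. Compound 3 is therefore estimated at 150 ug/mL, with a range from 50 ug/mL to 400 ug/mL, and most likely it will again reach only a limit.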

Compound 3, concentration for 50% growth inhibition: > 100 ug/mL
Compound 3: no number, only a limit; the forecaster's own chance of this, stated with the estimate: 70%; the middle value is on the limit's open side.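

Compound 1 and compound 3 both give only a limit in this assay, so no step can be read for fluoro in place of methoxy: the limit of > 100 ug/mL in this assay, at which 3 of the 3 values shown sit.

The compounds shown leave open the actual concentration for growth inhibition of each compound, and whether this change alters it at all.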